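A few compounds are considered here, and "the series" means these few. Any claim that something is new, unique, unknown or untested is made for them only; others in the source may bear on it.

Of the compounds shown here, two have been tested in a functional assay on NIH3T3 cells (Mus musculus); a lower number here means that less compound is needed, a higher number that more compound is needed for the effect. Compound 1, `CSCNC(=O)c1ccc(NCc2cncn2Cc2ccc(C#N)cc2)cc1-c1ccccc1`, carries a methylsulfanyl group on a saturated chain carbon bound to an amide-type nitrogen. In this assay compound 1 gives > 10 uM, which is a limit of the assay rather than a number. Compound 2, `COC(=O)[C@H](CCSC)NC(=O)c1ccc(CN(Cc2c[nH]cn2)Cc2c[nH]cn2)cc1-c1ccccc1C`, differs from compound 1 in several places at once. In this assay compound 2 gives > 10 uM, again a limit and not a number. Among the compounds with values here, compound 1 therefore stands at the limit of > 10 uM in this assay, at which 2 of the 2 values shown sit, and no measured step between two compounds exists to show how a single change moves the read-out.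

Compound 3, `N#CCNC(=O)c1ccc(NCc2cncn2Cc2ccc(C#N)cc2)cc1-c1ccccc1`, differs from compound 1 in one place: cyano in place of methylsulfanyl on a saturated chain carbon bound to an amide-type nitrogen. With both measured values sitting at a limit, the data give no direction for this change. The step this estimate means is a step that the limit leaves unreadable from compound 1 to compound 3, expected to stay within the usual scatter. This expectation rests on compound 1 standing at the limit of > 10 uM in this assay, at which 2 of the 2 values shown sit, with nothing measured to suggest movement. Compound 3 is accordingly expected to give about 15 uM in this assay, with a range from 3 uM to 60 uM, and most likely the assay will again report only a limit.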

Compound 3, concentration for half-maximal effect: > 10 uM
Compound 3 gave a limit, no number (the forecaster's own chance of this, stated with the estimate: 80%); the middle value does not contradict the limit.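

Compound 3 gives > 10 uM in this assay, a limit and not a number, and compound 1 also sits at a limit, so the step from cyano to methylsulfanyl between compound 1 and compound 3 cannot be read. The compounds shown leave open what structure, if any, would give a measurable value in this assay.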